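Cytotoxicity notes on a thiol-bearing series in MT4 cells

The source may hold more compounds than are shown below. What is called first, only, known or untested is meant among the compounds shown, and "the series" means these compounds.

Measured so far:
- compound 1, `Cc1nc(S)n(Nc2ccc(F)cc2)c1-c1ccccc1`: 220000 nM
- compound 2, `Cc1nc(S)n(Nc2cccc(Cl)c2)c1-c1cccc(Cl)c1`: 31000 nM
- compound 3, `CC1N=C(S)N(Nc2ccccc2)C1C`: 181000 nM

All three values come from a functional assay on MT4 cells (Homo sapiens) for cytotoxicity; on this read-out higher numbers stand for lower toxicity in this test and lower numbers for higher toxicity in this test. Compound 2 stands lowest of the three numbers; its gaps to compound 3 and to compound 1 both lie beyond the scatter, so compound 2 is the most cytotoxic compound measured here.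

Compound 4, `Cc1nc(S)n(Nc2cccc(Cl)c2)c1-c1ccc(Br)cc1`, has not been measured. It differs from compound 2 by 4-bromophenyl in place of 3-chlorophenyl on an aromatic carbon. Within the data shown here, no pair of measured compounds shows this change, so no measured step guides the expectation. Since one halogen-bearing phenyl replaces another, a step from compound 2 to compound 4 of a 1.1-fold higher number from compound 2 to compound 4 (0.05 log units; within the scatter) is expected, in no particular direction and not beyond the scatter. In this assay compound 4 is estimated at 35000 nM, with a range from 12000 nM to 100000 nM.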

Compound 4, half-maximal cytotoxic concentration: 33200 nM
For compound 4 the middle estimate is 1.1-fold (0.02 log units) above the measured one; measured number inside the range.
By their numbers in this assay, from the lowest: compounds 2 and 4 (each within the scatter of the next); then compounds 3 and 1 (each within the scatter of the next).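

In this assay, the first step read at this position, on an aromatic carbon of the five-membered aromatic ring, is a 1.1-fold higher number from compound 2 to compound 4 (0.03 log units; within the scatter) and stays within the scatter. The read-out does not separate 4-bromophenyl from 3-chlorophenyl here, although the halogen and its place on the phenyl change together, so neither change is read alone. Nothing at hand gives a reason for this outcome.

On these data alone, what plain phenyl, or a phenyl carrying an amine or a carboxylic acid, would do at this position in the setting of compound 2 stays open. So does the reading of 4-chlorophenyl or 3-bromophenyl there.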